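A few compounds are considered here, and "the series" means these few. Any claim that something is new, unique, unknown or untested is made for them only; others in the source may bear on it.

Going by the values given here, in a functional assay on HepG2 cells (Homo sapiens) for inhibition, read by MTT assay (on this read-out lower numbers stand for stronger inhibition and higher numbers for weaker inhibition), compound 1 `COc1cc2ncnc(Nc3ccc(NC(=O)c4cccc(C)c4)cc3)c2cc1OC` gives 7500 nM, which is the lowest of the two numbers measured so far in this small set. Its nearest neighbour, compound 2 `COc1cc2ncnc(Nc3ccc(NC(=O)c4ccc(C)cc4)cc3)c2cc1OC`, gives 25000 nM in this assay. Among the compounds with values here, the step of a 3.3-fold higher number from compound 1 to compound 2 (0.52 log units; beyond the scatter) is the only measured step here, and it shows that a change on the phenyl group sitting on the carbonyl carbon can shift the number beyond the usual scatter.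

Compound 3 `COc1cc2ncnc(Nc3ccc(NC(=O)c4cc(F)ccc4Br)cc3)c2cc1OC` differs from compound 1 by the change (2-bromo-5-fluorophenyl in place of 3-methylphenyl on a carbonyl carbon). Within the data shown here, no measured step here replaces a methyl with a bromine or a fluorine, so the step from compound 1 to compound 2 bears on it only loosely: it says that this part of the molecule is sensitive, not in which direction a halogen pair will push. The expectation is therefore a step of modest size in this assay, more likely towards a somewhat higher number than a lower one, with a real chance of none beyond the scatter.

Compound 3 is expected to give about 11000 nM in this assay, within a range of 3000 nM to 40000 nM, which would mean a step of a 1.5-fold higher number from compound 1 to compound 3 (0.17 log units; within the scatter).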

Compound 3, half-maximal inhibitory concentration: 22000 nM
The estimate for compound 3 lay 2.0-fold (0.30 log units) below the measured number, within the range that was stated.
By their numbers in this assay, from the lowest: compound 1; then compounds 3 and 2 (each within the scatter of the next).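

In this assay, replacing the 3-methylphenyl with 2-bromo-5-fluorophenyl gives a 2.9-fold higher number from compound 1 to compound 3 (0.47 log units; beyond the scatter), so a second and quite different group on the carbonyl carbon also ends up with a weaker number than compound 1. Set against the 4-methylphenyl, the same group gives a 1.1-fold lower number from compound 2 to compound 3 (0.06 log units; within the scatter), which means that compound 2 and compound 3 cannot be told apart on this read-out, although one carries a single methyl and the other a bromine and a fluorine. Of these three compounds, compound 1 therefore stands alone with the lowest number, and the position proves sensitive to the group placed there, though nothing measured alongside these compounds explains the pattern.

The compounds shown leave open whether a phenyl carrying an amine or a carboxylic acid, or a longer chain in place of the methyl of the 3-methylphenyl, would reach a lower number than compound 1. They also leave open whether a bromine alone or a fluorine alone would behave like the pair in compound 3.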